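Halogen swap on the chain of two cytotoxicity series

The source may hold more compounds than are shown below. What is called first, only, known or untested is meant among the compounds shown, and "the series" means these compounds.

Of the compounds shown here, three have been tested in a functional assay on HEL cells (Homo sapiens) for cytotoxicity; a lower number here means that less compound is tolerated, a higher number that more compound is tolerated. Compound 1 `O=c1[nH]c(=O)n([C@H]2C[C@H](O)[C@@H](CO)O2)cc1C#CCCCCCCCCCCl` carries a chloro end on its chain and gives 74000 nM. Compound 2 `O=c1[nH]c(=O)n([C@H]2C[C@H](O)[C@@H](CO)O2)cc1C#CCCCCCCCCCBr` differs from it by bromo in place of chloro on a saturated chain carbon, nine bonds along the chain from a triple-bonded carbon and gives 97000 nM; the step of a 1.3-fold higher number from compound 1 to compound 2 (0.12 log units; within the scatter). Compound 3 `O=c1nc2oc(CCCCCCCCCCl)cc2cn1[C@H]1C[C@H](O)[C@@H](CO)O1` is built on a different core; its difference from compound 1 is not broken down here. In this assay compound 3 gives 200000 nM, the highest of the three numbers, a step beyond the scatter from both compound 2 and compound 1.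

Compound 4 `O=c1nc2oc(CCCCCCCCCBr)cc2cn1[C@H]1C[C@H](O)[C@@H](CO)O1` has not been measured. It differs from compound 3 by bromo in place of chloro on a saturated chain carbon, nine bonds along the chain from an aromatic carbon. This is the same kind of change as from compound 1 to compound 2, but the place is not identical: there the saturated chain carbon lies nine bonds along the chain from a triple-bonded carbon, here nine bonds along the chain from an aromatic carbon. The single earlier occurrence of the change stayed within the scatter, and nothing among the three measured compounds points the other way, so compound 4 is expected to sit near compound 3, with a step of about a 1.2-fold higher number from compound 3 to compound 4 (0.06 log units; within the scatter) expected in this assay, set beside the earlier step from compound 1 to compound 2. For compound 4 the estimate in this assay is 230000 nM, with the range 110000 nM to 480000 nM regarded as likely.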

Compound 4, half-maximal cytotoxic concentration: > 50000 nM
Compound 4 was reported as a limit; the forecaster's own chance of this, stated with the estimate: 25%; the middle value is on the limit's open side.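

In this assay compound 4 is reported only as a limit, not as a number: the limit of > 50000 nM in this assay, at which 1 of the 4 values shown sits. The step from compound 3 to compound 4 cannot be read from this result. The compounds shown leave open whether bromo in place of chloro, on a saturated chain carbon, nine bonds along the chain from an aromatic carbon, changes the number in this assay on the core of compound 3.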